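Group on the sulfur: from compound 2 to compound 3

The source may report more compounds than this note shows. Statements on the series, on what has been measured and on what is new or still open speak of the compounds shown alone.

In a functional assay on A-375 cells (Homo sapiens) for inhibition, read by CCK-8 assay, with a stated time of 72 h, tested at 8 uM (a higher number here means more inhibition of growth at the concentration tested, a lower number less inhibition of growth), compound 1 (`COc1ccc(SCc2ccc(/C=C/C(=O)Nc3ccccc3N)cc2)cc1OC`) gives 46.4% and compound 2 (`Cc1ccc(SCc2ccc(/C=C/C(=O)Nc3ccccc3N)cc2)cc1`) gives 31.2% as the lower of the two numbers, beyond the scatter from compound 1. Compound 3 (`Nc1ccccc1NC(=O)/C=C/c1ccc(CSc2cccc3ccccc23)cc1`) keeps the shared core and differs from compound 2 only in the group on the sulfur: naphthalen-1-yl in place of 4-methylphenyl on a sulfur is the whole change, naphthalen-1-yl in place of 4-methylphenyl on a sulfur.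

Within the data shown here, the only measured step at this place is a number 15.2 percentage points lower from compound 1 to compound 2 (beyond the scatter) for 4-methylphenyl in place of 3,4-dimethoxyphenyl on a sulfur. Among the measured compounds shown here, no measured compound carries naphthalen-1-yl, and two compounds set no trend, so this step gives a scale rather than a firm direction. For the measured compounds named here, compound 2 holds the lower of only two numbers, so a modest rise is expected, no larger than the step seen at the sulfur so far. The expected change is a number 9.8 percentage points higher from compound 2 to compound 3 (within the scatter) as an estimate, upward and near the edge of the scatter. The estimate for compound 3 is 41% with a range from 25% to 57% in this assay readings.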

Compound 3, percent growth inhibition at one concentration: 36%
Compound 3: the middle estimate sits 5 percentage points above what was measured, and the stated range covers the measured number.
By their numbers in this assay, from the lowest: compounds 2 and 3 (each within the scatter of the next); then compound 1.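

In this assay the change to naphthalen-1-yl on the sulfur gives a number 4.8 percentage points higher from compound 2 to compound 3 (within the scatter), so a second six-membered aromatic ring of carbon only, in place of 4-methylphenyl, gives no separation at this position. The comparison with 3,4-dimethoxyphenyl gives a number 10.4 percentage points lower from compound 1 to compound 3 (beyond the scatter), which means that both carbon-only groups on the sulfur now stand beyond the scatter below compound 1, and none of the three compounds goes against this split. No measurement at hand accounts for the split or ties it to any property of these groups.

Three groups on the sulfur cannot show whether the higher reading of compound 1 needs both methoxy groups, and a single methoxy on the phenyl ring, a hydroxyl, an amine or a carboxylic acid would each test that question directly. On these data alone, it also remains open whether the sulfur position accepts a saturated ring such as cyclohexyl or a plain alkyl chain, and whether the readings at this single concentration would hold across a full dose range.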